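Chloro in place of hydrogen, carried across two cores

The compounds below may be only part of what the source reports. "The series", "measured", "known", "first", "only" and "open" are said of these compounds alone.

Compound 1 `CN1C(=O)C2(C(C#N)=C(N)Oc3cc4oc(-c5ccccc5)cc(=O)c4c(O)c32)c2ccccc21` and compound 2 `CN1C(=O)C2(C(C#N)=C(N)Oc3cc4oc(-c5ccccc5)cc(=O)c4c(O)c32)c2cccc(Cl)c21` share a core in which the amide-type nitrogen in the ring carries a methyl; compound 3 `N#CC1=C(N)Oc2cc3oc(-c4ccccc4)cc(=O)c3c(O)c2C12C(=O)Nc1ccccc12` and compound 4 `N#CC1=C(N)Oc2cc3oc(-c4ccccc4)cc(=O)c3c(O)c2C12C(=O)Nc1cc(Cl)ccc12` share a core in which that nitrogen carries a hydrogen. The two cores differ by hydrogen in place of methyl on an amide-type nitrogen in a ring.

In a functional assay on A549 cells (Homo sapiens) for antiproliferative activity, read by MTT assay, with a stated time of 48 h (a lower number here means a stronger inhibitor, a higher number a weaker inhibitor), compound 1 gives > 50000 nM, which is a limit of the assay and not a number. Compound 2 likewise gives > 50000 nM, again a limit. Within the data shown here, compound 3 gives 37600 nM, the only number among the three. The step of an at least 1.3-fold lower number from compound 1 to compound 3 (0.12 log units; that floor lies within the scatter) can be read only as a floor because of the limit of > 50000 nM in this assay, at which 2 of the 3 values shown sit.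

From compound 1 to compound 2 the change is chloro in place of hydrogen on an aromatic carbon, and the step that the two limits leave unreadable from compound 1 to compound 2. From compound 3 to compound 4 the change is chloro in place of hydrogen on an aromatic carbon, the same kind of change but not the same: in compound 2 the chloro sits ortho to a fused ring and meta to a fused ring, in compound 4 meta to a fused ring and para to a fused ring.

For compound 4 the step of a 1.1-fold higher number from compound 3 to compound 4 (0.03 log units; within the scatter) is expected, resting on compound 3 at 37600 nM and on the step that the two limits leave unreadable from compound 1 to compound 2 offering no readable size. Compound 4 is estimated at 40000 nM, with a range from 15000 nM to 100000 nM.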

Compound 4, half-maximal inhibitory concentration: 8470 nM
Compound 4: middle estimate off by 4.7-fold (0.67 log units), on the high side; the measured number lies below the stated range.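

In this assay, chloro in place of hydrogen on an aromatic carbon, meta to a fused ring and para to a fused ring, gives a 4.4-fold lower number from compound 3 to compound 4 (0.65 log units; beyond the scatter) in the core that carries hydrogen on the ring amide nitrogen, so in this one pair the change brings a modest gain that lies beyond the scatter. This shows what one chloro does at one place on one core, and it does not show that the gain carries over to the core with the methyl, where compound 2 also holds its chloro at a different place on the ring, so that even a readable step would not be the same change. The step from compound 1 to compound 2 cannot be read, and the methyl core gives no size to set beside the new step, because both of its compounds stand at a limit and not at a number: the limit of > 50000 nM in this assay, at which 2 of the 4 values shown sit.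

Still open, on these data alone, is whether chloro at the place it holds in compound 4 would lower the number in the core of compound 1, and whether the place it holds in compound 2 would do so in the core of compound 3. Also open, as far as these compounds go, is how fluoro, methoxy or an amine at the place of that chloro would compare with compound 4 in this assay.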